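The source may report more compounds than this note shows. Statements on the series, on what has been measured and on what is new or still open speak of the compounds shown alone.

Compound 1 `COc1cc(-c2nnc(SC)n2/N=C/c2ccccc2)cc(OC)c1OC` is the reference point of this series. In a functional assay on MCF7 cells (Homo sapiens) for cytotoxicity, read by MTT assay, with a stated time of 48 h (a lower number here means a stronger inhibitor, a higher number a weaker inhibitor), compound 1 gives > 200000 nM, which is a limit of the assay rather than a number. Compound 2 `COc1cc(-c2nnc(SCc3ccc(F)cc3)n2/N=C/c2ccccc2)cc(OC)c1OC` in this assay gives > 200000 nM, again a limit and not a number. Between them stands a step that the two limits leave unreadable from compound 1 to compound 2; both values sit at the limit of > 200000 nM in this assay, at which 2 of the 2 values shown sit. Compound 3 `COc1ccc(/C=N/n2c(SC)nnc2-c2cc(OC)c(OC)c(OC)c2)c(OC)c1` carries 2,4-dimethoxyphenyl in place of phenyl on a carbon with a double bond to nitrogen. Going by the values given here, no measured step bears on this change, and no numbers below the limit exist to anchor it. Compound 3 is therefore expected to remain at the limit, a step of a number no higher from compound 1 to compound 3 (the limit leaves the size open). The estimate for compound 3 is 200000 nM, with a range from 60000 nM to 400000 nM.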

Compound 3, half-maximal inhibitory concentration: > 200000 nM
Compound 3 ended at the assay's limit; the forecaster's own chance of this, stated with the estimate: 85%; the middle value sits exactly at the limit.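

Going by these compounds alone, compound 3 gives > 200000 nM, a limit of the assay and not a number, and no step from compound 1 to compound 3 can be read. The compounds shown leave open whether any change on the shared core gives a measurable value.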